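Removing One Hydroxy From a Catechol-Bearing Dihydropyrimidinone

The source may report more compounds than this note shows. Statements on the series, on what has been measured and on what is new or still open speak of the compounds shown alone.

In a functional assay on PC-3 cells (Homo sapiens) for inhibition, read by sulforhodamine B assay, with a stated time of 48 h (a higher number here means a weaker inhibitor of growth, a lower number a stronger inhibitor of growth), compound 3 `CCOC(=O)C1=C(C)NC(=O)NC1c1ccc(O)c(O)c1` gives 18.2 ug/mL. Compound 2 `CCOC(=O)C1=C(C)NC(=S)NC1c1cc(OC)c(O)c(OC)c1` gives 19 ug/mL and compound 1 `CCOC(=O)C1=C(C)NC(=S)NC1c1ccc(O)c(O)c1` gives 25 ug/mL; both of these numbers sit within the scatter of the number for compound 3, so the three compounds cannot be separated by this assay. Compound 4 `CCOC(=O)C1=C(C)NC(=O)NC1c1ccc(O)cc1` differs from compound 3 in one place: hydrogen in place of hydroxy on an aromatic carbon. Among the compounds with values here, no measured pair in this set shows the effect of such a change, so the size of the step is open. The account expects the step of a 1.4-fold higher number from compound 3 to compound 4 (0.14 log units; within the scatter) to be small, perhaps toward a slightly higher number, and not clearly beyond the scatter. For compound 4 the expected result in this assay is 25 ug/mL, estimated to fall between 12 ug/mL and 55 ug/mL.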

Compound 4, concentration for 50% growth inhibition: 136 ug/mL
For compound 4 the middle estimate is 5.4-fold (0.74 log units) below the measured one; the measured number lies above the stated range.
By their numbers in this assay, from the lowest: compounds 3, 2 and 1 (each within the scatter of the next); then compound 4.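

In this assay, within the data shown here, hydrogen in place of hydroxy on this aromatic carbon, ortho to a hydroxy group and meta to a large group, gives a 7.5-fold higher number from compound 3 to compound 4 (0.87 log units; beyond the scatter) and is the first single-place change in the set. It shows that this position matters to growth inhibition: compound 4 keeps the other hydroxy, yet it is a weaker inhibitor than compound 3. No measurement shown explains the step. Open, as far as these compounds go, is whether an amine or a fluorine at this position would stay near compound 3 or fall toward compound 4.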